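Compound 3 to compound 4: chloro leaves, diethylamino enters

The compounds below may be only part of what the source reports. "The series", "measured", "known", "first", "only" and "open" are said of these compounds alone.

In an ADME assay on BJ cells (Homo sapiens) for cytotoxicity, with a stated time of 72 h (on this read-out higher numbers stand for an effect only at larger amounts of compound and lower numbers for an effect already at smaller amounts), compound 1 `Nc1cc2c(-n3nc(-c4ccccn4)nc3N)ncnc2cc1Cl` gives 27000 nM. For compound 2 `COc1cc2ncnc(-n3nc(-c4ccccn4)nc3N)c2cc1N` the entry is "not determined" (no result reported). Compound 3 `COc1cc2nc(Cl)nc(-n3nc(-c4ccccn4)nc3N)c2cc1OC` reads > 13000 nM, which is a limit and not a number. For the measured compounds named here, no two measured compounds differ in one place, so the series offers no measured step to draw on. Compound 4 `CCN(CC)c1nc(-n2nc(-c3ccccn3)nc2N)c2cc(OC)c(OC)cc2n1` follows from compound 3 by diethylamino in place of chloro on an aromatic carbon, between two ring nitrogen atoms. No step beyond the usual scatter is expected in this assay, in either direction. The expected change is a step that the limit leaves unreadable from compound 3 to compound 4. Going by the values given here, the only firm number remains compound 1 at 27000 nM. Compound 4 is estimated at 20000 nM, with an expected range of 8000 nM to 50000 nM.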

Compound 4, half-maximal effective concentration: > 9000 nM
Compound 4: a limit, no number (the forecaster's own chance of this, stated with the estimate: 40%); the middle value does not contradict the limit.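

In this assay compound 3 and compound 4 both carry limits, not numbers, so no step can be read between them. The compounds shown leave open whether diethylamino in place of chloro shifts the read-out at all, and in which direction.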